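Replacing dimethylamino with cyano on the distal phenyl ring

The source may report more compounds than this note shows. Statements on the series, on what has been measured and on what is new or still open speak of the compounds shown alone.

Of the compounds shown here, three sharing one core have been measured in an assay with sodium-dependent dopamine transporter (Rattus norvegicus) as the target; on this read-out lower numbers stand for stronger inhibition and higher numbers for weaker inhibition. Compound 1 `COC(=O)C1C2CCC3CCC1N(C/C2=C\c1ccc(-c2ccc(C)cc2)cc1)C3` gives 214 nM. Compound 2 `COC(=O)C1C2CCC3CCC1N(C/C2=C\c1ccc(-c2cccc(Cl)c2)cc1)C3` gives 89 nM. Compound 3 `COC(=O)C1C2CCC3CCC1N(C/C2=C\c1ccc(-c2ccc(N(C)C)cc2)cc1)C3` gives 1050 nM, the highest of the three numbers; the nearest is compound 1, because a 4.9-fold higher number from compound 1 to compound 3 (0.69 log units; beyond the scatter), and the furthest is compound 2, because a 12-fold higher number from compound 2 to compound 3 (1.07 log units; beyond the scatter).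

Compound 4 `COC(=O)C1C2CCC3CCC1N(C/C2=C\c1ccc(-c2ccc(C#N)cc2)cc1)C3` has not yet been measured in this assay. It differs from compound 3 in one place: cyano in place of dimethylamino on an aromatic carbon. Both steps that reach compound 3 bear on this change, since each of them arrives at the dimethylamino group that now leaves. The step of a 4.9-fold higher number from compound 1 to compound 3 (0.69 log units; beyond the scatter) and the step of a 12-fold higher number from compound 2 to compound 3 (1.07 log units; beyond the scatter) both move toward dimethylamino and both raise the number, so moving away from that group is expected to lower it. Among the compounds with values here, the size is uncertain: no measured compound carries cyano, and the substituent that enters is not the one in compound 1 or compound 2.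

Compound 4 is therefore expected to come in at 250 nM, in a range from 80 nM to 800 nM, which is the estimated step of a 4.2-fold lower number from compound 3 to compound 4 (0.62 log units; beyond the scatter) in this assay.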

Compound 4, inhibition constant: 47 nM
Compound 4: middle estimate off by 5.3-fold (0.73 log units), on the high side, outside the stated range (below it).
By their numbers in this assay, from the lowest: compounds 4 and 2 (each within the scatter of the next); then compound 1; then compound 3.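

In this assay, a 22-fold lower number from compound 3 to compound 4 (1.35 log units; beyond the scatter) is wider than either step that had arrived at dimethylamino, so this aromatic carbon, para to a large group, proves more sensitive to its substituent than compounds 1, 2 and 3 could show. The earlier compounds shown here showed only that dimethylamino stood apart from methyl at this carbon, whereas a 4.6-fold lower number from compound 1 to compound 4 (0.66 log units; beyond the scatter) now separates two further groups there, and a 1.9-fold lower number from compound 2 to compound 4 (0.28 log units; within the scatter) places the 4-cyanophenyl compound level with the 3-chlorophenyl compound, which the earlier 4-substituted compounds had not matched. Dimethylamino and cyano have the same counts of hydrogen-bond donors and acceptors and neither carries a net charge, so those counts do not separate them, and nothing shown here explains the difference between the two groups.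

With only methyl, dimethylamino and cyano at this carbon, the compounds shown leave open where a methoxy group, a primary amide or a carboxylic acid would fall on the same scale. They also leave open whether a nitrile on the carbon that carries the chlorine in compound 2 would give a number like that of compound 4.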